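The compounds below may be only part of what the source reports. "The series", "measured", "known", "first", "only" and "open" are said of these compounds alone.

Measured so far in a functional assay on HT-29 cells (Homo sapiens) for cytotoxicity, read by MTT assay, with a stated time of 72 h; a higher number here means a weaker inhibitor of growth, a lower number a stronger inhibitor of growth:
- compound 1 `CSc1ccc(CNc2nc([SeH])nc3ccccc23)cc1`: 42900 nM
- compound 2 `CSc1ccc(CNc2nc(SC)nc3ccccc23)cc1`: 34700 nM

Both compounds share one core and differ only in the group on the aromatic carbon between the two ring nitrogens. Compound 1 carries a selenium atom there, compound 2 a methylsulfanyl group. The step from one to the other, a 1.2-fold lower number from compound 1 to compound 2 (0.09 log units; within the scatter), is within the scatter, so compound 2 and compound 1 cannot be told apart in this assay on the numbers shown.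

Compound 3 `CSc1ccc(CNc2nc([Se]C)nc3ccccc23)cc1` is the next variation at the same place: a group of 2 heavy atoms (1 carbon, 1 selenium; no ring) in place of a group of 2 heavy atoms (1 carbon, 1 sulfur; no ring), on an aromatic carbon. In plain words, the sulfur of the methylsulfanyl group is exchanged for selenium, with the methyl kept.

Going by the values given here, the only measured step that bears on this change is the one between compound 1 and compound 2, where exchanging selenium for sulfur with a methyl added made no difference beyond the scatter in this assay. With so little movement from a related exchange at the same position, no step beyond the scatter is expected here. Compound 3 is therefore estimated at 35000 nM, with a range from 15000 nM to 80000 nM, corresponding to an expected step of a 1.0-fold higher number from compound 2 to compound 3 (0.00 log units; within the scatter).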

Compound 3, concentration for 50% growth inhibition: 72700 nM
For compound 3 the middle estimate is 2.1-fold (0.32 log units) below the measured one; low and high end bracket the measured number.
By their numbers in this assay, from the lowest: compounds 2, 1 and 3 (each within the scatter of the next, the first and the last beyond it).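

In this assay, this position proves sensitive to the atom that carries the methyl: exchanging the sulfur of the methylsulfanyl group for selenium gives a 2.1-fold higher number from compound 2 to compound 3 (0.32 log units; beyond the scatter), a modest change and the only step among these compounds that lies beyond the scatter. Placing a methyl on the selenium gives a 1.7-fold higher number from compound 1 to compound 3 (0.23 log units; within the scatter), which stays within the scatter, so this assay cannot show that the methyl itself matters when selenium is present. The data shown include no separate measurement that could explain why the sulfur and selenium compounds differ, so the result stands here as an observation without an established cause.

The compounds shown leave open how this position would respond to a quite different group, such as an amine, a hydroxyl group or a morpholine ring, and whether any such group would bring a larger step in either direction. They also leave open whether the modest difference between sulfur and selenium would persist if the methyl gave way to a longer chain, such as ethyl or benzyl.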